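Swapping the ring group on compound 1

The source may hold more compounds than are shown below. What is called first, only, known or untested is meant among the compounds shown, and "the series" means these compounds.

Compound 1 `CC(C)C(c1ccc(-c2ccc3cccc(F)c3c2)[nH]c1=O)C1NC(=O)NC1=O`: 0.578 h
Compound 2 `CC(C)/C(=C1/SC(=O)NC1=O)c1ccc(-c2ccc3cccc(F)c3c2)[nH]c1=O`: > 3 h, a limit of the assay
Compound 3 `O=C1NC(=O)/C(=C/C(Cc2ccccc2)c2ccc(-c3ccc4cccc(F)c4c3)[nH]c2=O)O1`: 1.3 h

In an ADME assay on microsomes from liver (Homo sapiens) for metabolic stability (on this read-out higher numbers stand for a longer-lived compound and lower numbers for a shorter-lived compound), compound 1 has the lowest number, 0.578 h. Compound 3 stands higher at 1.3 h, a gap beyond the usual scatter.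

Compound 4 `CC(C)C(/C=C1/C(=O)NC(=O)N1C)c1ccc(-c2ccc3cccc(F)c3c2)[nH]c1=O` has not been measured. It differs from compound 1 in one place: a group of 9 heavy atoms (5 carbon, 2 nitrogen, 2 oxygen; one five-membered non-aromatic ring with 2 hetero atoms) in place of a group of 7 heavy atoms (3 carbon, 2 nitrogen, 2 oxygen; one five-membered non-aromatic ring with 2 hetero atoms), on a saturated chain carbon bound to an aromatic carbon and a saturated chain carbon. Compound 3, at 1.3 h, also has a double bond leading to its five-membered ring, so a moderate rise beyond the scatter is expected. The expected change is a 2.4-fold higher number from compound 1 to compound 4 (0.38 log units; beyond the scatter). For compound 4 the estimated half-life is 1.4 h, with an expected range of 0.6 h to 3 h.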

Compound 4, half-life: > 3 h
Compound 4: no number, only a limit; the forecaster's own chance of this, stated with the estimate: 15%; at least 2.1-fold (0.33 log units) between middle value and limit.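

In this assay, putting the larger ring group in place of the 2,5-dioxoimidazolidin-4-yl group on this saturated chain carbon gives an at least 5.1-fold higher number from compound 1 to compound 4 (0.71 log units; beyond the scatter). This is the first single-place step shown here, and it shows that half-life responds strongly to the group at this position. For compound 4, > 3 h is a limit of the assay and not a number, so the full size of the step stays unknown: the limit of > 3 h in this assay, at which 2 of the 4 values shown sit.

The new group differs in its carbon count, double bonds and hydrogen-bond donors all at once, and the compounds shown do not separate these changes. From the compounds shown here alone, how an amine or a carboxylic acid would fare at this position also remains open.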